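A Methyl on the Ring Amine, Tried on Two Cores

This account rests on a few compounds, and the source may have more. Where it says the series, first, only, none or still open, it means among the compounds named here.

Measured so far in a functional assay on A2780 cells (Homo sapiens) for cytotoxicity, read by MTT assay, with a stated time of 48 h; a lower number here means a stronger inhibitor, a higher number a weaker inhibitor:
compound 1 `CCn1cc(-c2nc3ccccc3[nH]2)c(=O)c2cc(F)c(N3CCNCC3)cc21` — 800 nM
compound 2 `CCn1cc(-c2nc3ccccc3[nH]2)c(=O)c2cc(F)c(N3CCN(C)CC3)cc21` — > 5010000 nM (a limit of this assay, not a number)
compound 3 `CCn1cc(-c2nc3ccc([N+](=O)[O-])cc3s2)c(=O)c2cc(F)c(N3CCNCC3)cc21` — 700 nM

Compound 1 and compound 3 share a common framework; how their two cores differ is not broken down here. In this assay compound 1 gives 800 nM, and compound 3 gives 700 nM, so the two sit within the usual scatter of each other. Compound 2 is only reported at a limit, (the limit of > 5010000 nM in this assay, at which 1 of the 3 values shown sits). The change from compound 1 to compound 2 is methyl in place of hydrogen on an amine nitrogen in a ring, and it brings an at least 6200-fold higher number from compound 1 to compound 2 (3.79 log units; beyond the scatter).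

Compound 4 `CCn1cc(-c2nc3ccc([N+](=O)[O-])cc3s2)c(=O)c2cc(F)c(N3CCN(C)CC3)cc21` is not yet measured. It differs from compound 3 by methyl in place of hydrogen on an amine nitrogen in a ring, the same change as from compound 1 to compound 2. Because that earlier change gave an at least 6200-fold higher number from compound 1 to compound 2 (3.79 log units; beyond the scatter), a step of similar size is expected here, a 7100-fold higher number from compound 3 to compound 4 (3.85 log units; beyond the scatter). For compound 4 in this assay the expected value is 5000000 nM, between 50000 nM and 10000000 nM, most likely reported only as a limit.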

Compound 4, half-maximal inhibitory concentration: 4300 nM
Beside the measured number, compound 4's estimate is 1200-fold (3.07 log units) above it, and the stated range ends above it.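

In this assay, methyl in place of hydrogen on the ring amine nitrogen also raises the number on the second core, with a 6.1-fold higher number from compound 3 to compound 4 (0.79 log units; beyond the scatter), so the direction of the change carries over from one core to the other, but its size does not: the same change on two cores in this assay, an at least 6200-fold higher number (3.79 log units; beyond the scatter) from compound 1 to compound 2 and a 6.1-fold higher number (0.79 log units; beyond the scatter) from compound 3 to compound 4, at least 1000-fold (3.00 log units) apart, beyond the scatter of two such steps

Compound 2 is reported only at a limit, > 5010000 nM. Two cores show that the effect of this small change depends on the core it is placed on, but they give no general rule for the series and do not reveal which part of the cores is responsible for the difference.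

Still open, going by these compounds, is how a longer chain, such as ethyl or propyl, or an acetyl group on that same nitrogen would compare with hydrogen and methyl on these two cores. On these data alone, it is also open how large the methyl step would be on a third core.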